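A few compounds are considered here, and "the series" means these few. Any claim that something is new, unique, unknown or untested is made for them only; others in the source may bear on it.

Compound 2 `COc1ccc(-c2nc(-c3ccc(Br)cc3)c(CC(=O)O)s2)cc1` gives the lowest number of the three measured in an in vitro assay on COS-7 cells for displacement of a labelled ligand from prostaglandin D2 receptor 2 (Homo sapiens) (a lower number here means a stronger inhibitor, a higher number a weaker inhibitor), at 390 nM. Compound 3 `CN(C)c1ccc(-c2nc(-c3ccc(Br)cc3)c(CC(=O)O)s2)cc1` sits close to it, giving 460 nM, and the step of a 1.2-fold higher number from compound 2 to compound 3 (0.07 log units; within the scatter) is within the scatter. Compound 1 `COc1ccc(-c2nc(-c3ccc(OC)cc3)c(CC(=O)O)s2)cc1` is the furthest away, giving 4100 nM, and the step of an 11-fold lower number from compound 1 to compound 2 (1.02 log units; beyond the scatter) is the only large one among the measured pairs.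

Compound 4 `COc1ccc(-c2nc(-c3ccccc3)c(CC(=O)O)s2)cc1` differs from compound 2 by hydrogen in place of bromo on an aromatic carbon, so the bromo group whose arrival from methoxy made the large step from compound 1 to compound 2 is now taken away entirely. The step of an 11-fold lower number from compound 1 to compound 2 (1.02 log units; beyond the scatter) bears on this directly: a bromo group at this position is associated with a much lower number than a methoxy group. Within the data shown here, no measured pair shows a bare hydrogen at this position, so how the phenyl ring compares with either substituted ring is not known from these data. Given the size of the step from compound 1 to compound 2, a loss of the bromo group is expected to move the number upward, though by less than that step. Compound 4 is therefore estimated at 1500 nM, within 500 nM to 5000 nM, an expected step of a 3.8-fold higher number from compound 2 to compound 4 (0.59 log units; beyond the scatter).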

Compound 4, half-maximal inhibitory concentration: 820 nM
Estimate against measurement, compound 4: 1.8-fold (0.26 log units) above; low and high end bracket the measured number.
By their numbers in this assay, from the lowest: compounds 2, 3 and 4 (each within the scatter of the next, the first and the last beyond it); then compound 1.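

The phenyl ring of compound 4 gives this position a third group on the same core, and it shows that the bare ring already carries most of the gain seen with bromo. Taking the bromo away costs only a 2.1-fold higher number from compound 2 to compound 4 (0.32 log units; beyond the scatter) in this assay, a modest step, whereas replacing the methoxy with hydrogen gives a 5.0-fold lower number from compound 1 to compound 4 (0.70 log units; beyond the scatter) at the same place, so the larger part of the gap from compound 1 to compound 2 lies on the methoxy side of the hydrogen compound, and the order at this position runs from bromo through hydrogen to methoxy, with bromo giving the lowest number. Nothing measured here explains why these three groups fall in this order.

Still open is how other groups on this ring would fall in that order, such as chloro, fluoro, methyl or an amine, since the three groups shown cannot tell whether any of these would go lower than bromo. On these data alone, it also remains open whether the same order holds when dimethylamino, rather than methoxy, stands on the other aromatic ring.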